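This account rests on a few compounds, and the source may have more. Where it says the series, first, only, none or still open, it means among the compounds named here.

Two compounds have so far been measured in a functional assay on RAW264.7 cells (Mus musculus) for inhibition, read by ELISA, with stated times of 30 min and 24 h; a higher number here means a weaker inhibitor, a lower number a stronger inhibitor:

Compound 1, `COc1ccc(/C=C/c2cc(OC)cc(OC)c2/C=C/C(=O)/C=C/c2ccc(OCCCN(C)C)cc2)cc1`, gives 2150 nM.
Compound 2, `COc1ccc(/C=C/c2cc(OC)cc(OC)c2/C=C/C(=O)/C=C/c2cccc(OC)c2OC)cc1`, gives 2480 nM.

For the measured compounds named here, compound 2 has the higher of these two numbers, yet its only neighbour, compound 1, differs from it by an amount that lies within the usual scatter, so the two cannot be told apart on these measurements. Compound 3, `COc1ccc(/C=C/c2cc(OC)cc(OC)c2/C=C/C(=O)/C=C/c2ccc(OC)cc2OC)cc1`, has not been measured yet. It is built from the same atoms as compound 2, joined differently: 2,4-dimethoxyphenyl in place of 2,3-dimethoxyphenyl on a double-bonded chain carbon bound to a double-bonded chain carbon. Going by the values given here, both the group that leaves and the group that enters are a phenyl ring bearing two methoxy groups; the only change is which ring positions the two methoxy groups occupy, as named in the groups themselves. Among the compounds with values here, no step between measured compounds shows what such a rearrangement does, so there is nothing to scale an expectation from. The expected step from compound 2 to compound 3 in this assay is a 1.1-fold lower number from compound 2 to compound 3 (0.03 log units; within the scatter), which is none beyond the scatter. Compound 3 is therefore estimated to give 2300 nM in this assay, with a range from 1000 nM to 5500 nM.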

Compound 3, half-maximal inhibitory concentration: 3030 nM
Compound 3: the middle estimate sits 1.3-fold (0.12 log units) below what was measured; the measured number falls inside the stated range.
By their numbers in this assay, from the lowest: compounds 1, 2 and 3 (each within the scatter of the next).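

Replacing 2,3-dimethoxyphenyl with 2,4-dimethoxyphenyl on a double-bonded chain carbon bound to a double-bonded chain carbon gives a 1.2-fold higher number from compound 2 to compound 3 (0.09 log units; within the scatter) in this assay. For the compounds shown here, this is the first step that compares two compounds differing in one place, and it shows that this particular rearrangement of the same atoms produces no difference that can be separated from ordinary measurement scatter. No independent measurement is available to explain this result.

The step covers only two arrangements of two methoxy groups on one ring, so it cannot show whether this place in the molecule would stay just as unresponsive in this assay to a different kind of group. Going by these compounds, a carboxylic acid, a fluorine atom or a single hydroxy group on that ring would be a much larger change than this one, and how the number would respond to any of them remains open.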